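Reshaping One Aryl Group on the Shared Core

The compounds below may be only part of what the source reports. "The series", "measured", "known", "first", "only" and "open" are said of these compounds alone.

In an assay on isolated protein for inhibition of Intestinal-type alkaline phosphatase (Bos taurus), read by spectrophotometry, with stated times of 7 min and 15 min (a higher number here means a weaker inhibitor, a lower number a stronger inhibitor), compound 1 `CCCCCc1cc(=O)c2cc([N+](=O)[O-])ccc2n1Cc1ccc(OC)cc1` gives 1380 nM, compound 2 `COc1ccc(Cn2c(-c3ccc(C)cc3)c(Br)c(=O)c3cc([N+](=O)[O-])ccc32)cc1` gives 2430 nM, and compound 3 `CCc1ccc(-c2c(-c3ccc(C)cc3)n(Cc3ccc(OC)cc3)c3ccc([N+](=O)[O-])cc3c2=O)cc1` gives 5750 nM, the highest of the three numbers and thus the weakest inhibitor among them. Compound 4 `COc1ccc(Cn2c(-c3ccc(C)cc3)c(-c3cc(C)cc(C)c3)c(=O)c3cc([N+](=O)[O-])ccc32)cc1` differs from compound 3 in a single place: 3,5-dimethylphenyl in place of 4-ethylphenyl on an aromatic carbon. Among the compounds with values here, the only measured step at that position is a 2.4-fold higher number from compound 2 to compound 3 (0.37 log units; beyond the scatter), which exchanged bromo for 4-ethylphenyl; no measured step exchanges one aryl group for another of equal size, so there is no direct guide. Compound 4 is expected to remain close to compound 3 in this assay, a step of a 1.2-fold lower number from compound 3 to compound 4 (0.06 log units; within the scatter), giving an estimate of 5000 nM with a likely range from 2000 nM to 14000 nM.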

Compound 4, half-maximal inhibitory concentration: 28700 nM
The estimate for compound 4 lay 5.7-fold (0.76 log units) below the measured number, outside the stated range (above it).
By their numbers in this assay, from the lowest: compounds 1 and 2 (each within the scatter of the next); then compound 3; then compound 4.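

In this assay, this position tells apart two aryl groups built from the same atoms: rearranging 4-ethylphenyl into 3,5-dimethylphenyl gives a 5.0-fold higher number from compound 3 to compound 4 (0.70 log units; beyond the scatter). Set against bromo, 3,5-dimethylphenyl gives a 12-fold higher number from compound 2 to compound 4 (1.07 log units; beyond the scatter), so the arrangement of the carbons on this aryl group matters here, not only their count. No measurement at hand explains the difference. The compounds shown leave open whether plain phenyl, or an aryl group carrying an amine or a carboxylic acid, would bring the number back toward that of compound 2.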